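A few compounds are considered here, and "the series" means these few. Any claim that something is new, unique, unknown or untested is made for them only; others in the source may bear on it.

Compound 3, with the structure `O=C(CCN1C(=O)CSc2ccccc21)NCCCN1CCN(c2ccc([N+](=O)[O-])cc2)CC1`, was tested in a functional assay on IMR-32 cells (Homo sapiens) for inhibition, read by sulforhodamine B assay, with a stated time of 48 h (on this read-out higher numbers stand for weaker inhibition of growth and lower numbers for stronger inhibition of growth), where it gives 460 nM. Among the two values that are plain numbers it is the lowest: the nearest is compound 1, with the structure `O=C(CCN1C(=O)CSc2ccccc21)N1CCN(c2ccc(F)cc2)CC1`, which gives 10000 nM in this assay. Compound 2, with the structure `O=C(CCN1C(=O)CSc2ccccc21)N1CCN(c2ccccc2)CC1`, gives in this assay < 10 nM, which is a limit of the assay and not a number; this is the limit of < 10 nM in this assay, at which 1 of the 3 values shown sits.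

Compound 4 has the structure `COc1ccccc1N1CCN(CCCNC(=O)CCN2C(=O)CSc3ccccc32)CC1` and has not yet been measured. It differs from compound 3 by 2-methoxyphenyl in place of 4-nitrophenyl on an amine nitrogen in a ring. Within the data shown here, the only measured step that touches the same part of the shared core is the one from compound 1 to compound 2, which is an at least 1000-fold lower number from compound 1 to compound 2 (3.00 log units; beyond the scatter); there the group on the aromatic ring attached to the ring nitrogen was changed, and the effect was large. Among the measured compounds shown here, that step is, however, a different exchange from the one between compound 3 and compound 4, so it shows only that changes at this place can move the number a long way, without telling in which direction.

The expectation for compound 4 in this assay is therefore wide, with the step from compound 3 to compound 4 estimated as a 1.5-fold lower number from compound 3 to compound 4 (0.19 log units; within the scatter). Compound 4 is expected to give about 300 nM, within a range from 30 nM to 3000 nM.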

Compound 4, concentration for 50% growth inhibition: > 100000 nM
Compound 4: a limit, no number; the forecaster's own chance of this, stated with the estimate: 10%; middle value at least 330-fold (2.52 log units) away from the limit.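

In this assay, putting 2-methoxyphenyl in place of 4-nitrophenyl on the amine nitrogen in the ring gives an at least 210-fold higher number from compound 3 to compound 4 (2.33 log units; beyond the scatter), a large loss of growth inhibition. Among these compounds, the earlier step at this place, an at least 1000-fold lower number from compound 1 to compound 2 (3.00 log units; beyond the scatter), exchanged only fluoro and hydrogen on the aromatic ring and belonged to compounds with a different link to the shared core, so the new step shows that this position is just as sensitive when that link is the one found in compound 3 and the whole substituted phenyl group is exchanged. Compound 4 stands at a limit of the assay, not at a number: the limit of > 100000 nM in this assay, at which 1 of the 4 values shown sits.

The compounds shown leave open whether this step comes from the kind of group on the phenyl ring or from where it sits, since nitro leaves and methoxy enters at different ring places in a single exchange. A 4-methoxyphenyl or a 2-nitrophenyl group on the same nitrogen would separate these two changes, and nothing here tells why the number moves so far.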